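Working notes: a longer chain on compound 1

The compounds below may be only part of what the source reports. "The series", "measured", "known", "first", "only" and "open" are said of these compounds alone.

Measured in a functional assay on PC-3 cells (Homo sapiens) for inhibition, read by MTT assay, with stated times of 18 h and 4 h; on this read-out lower numbers stand for stronger inhibition and higher numbers for weaker inhibition:
- compound 1 `CCCCCCCCOP(=O)(O)OCCSC(=S)N1CCCCC1`: > 100000 nM (a limit, not a number)
- compound 2 `CCCCCCCCOP(=O)(O)OCCSC(=S)N1CCCCCC1`: 56800 nM

Compound 1 has no number in this assay, only a limit, and the limit of > 100000 nM in this assay, at which 1 of the 2 values shown sits, is the whole of what can be said about its standing. Compound 3 `CCCCCCCCCCCCCCCCOP(=O)(O)OCCSC(=S)N1CCCCC1` keeps the core of compound 1 and its piperidin-1-yl on the thiocarbonyl carbon. The change is octyl in place of hydrogen on a saturated chain carbon, eight bonds along the chain from an oxygen on an unsaturated carbon, which can also be read as methyl to nonyl.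

For the measured compounds named here, the only measured step is an at least 1.7-fold lower number from compound 1 to compound 2 (0.24 log units; that floor lies within the scatter). It alters the group on the thiocarbonyl carbon and leaves the chain untouched, so it gives only weak guidance here. Going by the values given here, no measured step alters the chain. Compound 2 gives 56800 nM, so a number within reach of this assay is expected for compound 3 as well, though with little support.

The estimated step is an at least 3.3-fold lower number from compound 1 to compound 3 (0.52 log units; beyond the scatter), towards stronger inhibition, and it may prove small. For compound 3 the expected value is 30000 nM, with an estimated range of 8000 nM to 100000 nM.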

Compound 3, half-maximal inhibitory concentration: 34300 nM
Compound 3: the middle estimate sits 1.1-fold (0.06 log units) below what was measured; the range from low to high includes it.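

In this assay, the longer chain gives an at least 2.9-fold lower number from compound 1 to compound 3 (0.46 log units; beyond the scatter), so the chain of compound 1 responds to this change, which the earlier step could not show as it left the chain untouched. For the compounds shown here, the change is octyl in place of hydrogen on a saturated chain carbon, eight bonds along the chain from an oxygen on an unsaturated carbon, with the piperidin-1-yl on the thiocarbonyl carbon held constant, and it is the first step that is printed as beyond the usual scatter. Its full size stays unknown and only its floor can be read, because compound 1 carries a limit and not a number: the limit of > 100000 nM in this assay, at which 1 of the 3 values shown sits.

With only two chain lengths shown, the course of the number between and beyond them remains open, for instance with a dodecyl chain or an octadecyl chain in place of those in compound 1 and compound 3. Also open, going by these compounds, is whether the same octyl change would lower the number when azepan-1-yl sits on the thiocarbonyl carbon, as it does in compound 2.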